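A few compounds are considered here, and "the series" means these few. Any claim that something is new, unique, unknown or untested is made for them only; others in the source may bear on it.

Measured so far in a functional assay on MDA-MB-231 cells (Homo sapiens) for cytotoxicity, read by ELISA, with a stated time of 2 days (on this read-out higher numbers stand for weaker inhibition and lower numbers for stronger inhibition), for this series:
- compound 1 `Oc1cccc(-c2cc(-c3ccccc3)cc(-c3ccco3)n2)c1` gives 13700 nM
- compound 2 `Oc1ccc(-c2cc(-c3ccccc3)cc(-c3ccsc3)n2)cc1` gives 5700 nM

Compound 2 holds the lower of the two numbers, and compound 1 stands higher by a margin beyond the scatter. Next in line is compound 3 `Oc1ccc(-c2cc(-c3ccccc3)cc(-c3ccco3)n2)cc1` with furan-2-yl in place of thiophen-3-yl on an aromatic carbon, next to the ring nitrogen (furan-2-yl in place of thiophen-3-yl on an aromatic carbon). Among the measured compounds shown here, no step between measured compounds that differ in one place is available, so any forecast rests on thin evidence. For the measured compounds named here, compound 1 also carries furan-2-yl and gives 13700 nM as the only reference with that group. Compound 1 and compound 2 differ in more than one place, so their gap cannot be assigned to this group alone. In this assay a modest step toward a higher number is expected, possibly not beyond the scatter. The expected size is a 1.4-fold higher number from compound 2 to compound 3 (0.15 log units; within the scatter) as estimated here. For compound 3 the estimate is 8000 nM with an expected range from 3500 nM to 18000 nM on this read-out.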

Compound 3, half-maximal inhibitory concentration: 1400 nM
Beside the measured number, compound 3's estimate is 5.7-fold (0.76 log units) above it; the whole stated range lies above it.
By their numbers in this assay, from the lowest: compound 3; then compound 2; then compound 1.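

In this assay the aromatic carbon next to the ring nitrogen does not treat its two five-membered rings alike: furan-2-yl in place of thiophen-3-yl gives a 4.1-fold lower number from compound 2 to compound 3 (0.61 log units; beyond the scatter), although the two groups match in heavy-atom count and in hydrogen-bond donor and acceptor counts. With furan-2-yl held fixed, 4-hydroxyphenyl in place of 3-hydroxyphenyl gives a 9.8-fold lower number from compound 1 to compound 3 (0.99 log units; beyond the scatter), so the series now has a one-place reading for each of the two groups, and both steps lead down to compound 3, which holds the lowest number of the three by margins beyond the scatter. No measurement on hand bears on why either change moves the number, so both steps stand as observations only.

On these data alone, each change is read on a single background, so it remains open whether furan-2-yl in place of thiophen-3-yl gives a step of similar direction alongside 3-hydroxyphenyl, or whether 4-hydroxyphenyl in place of 3-hydroxyphenyl does so alongside thiophen-3-yl. Also open, as far as these compounds go, is how this assay would read an amine or a carboxylic acid in place of the hydroxy group on the 4-hydroxyphenyl group, or a morpholine ring in place of furan-2-yl.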